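This account rests on a few compounds, and the source may have more. Where it says the series, first, only, none or still open, it means among the compounds named here.

Measured so far:
compound 1, `O=C(CCN1CCC(Cc2ccccc2)CC1)Nc1ccccc1Cl` — 0.2 ug/mL
compound 2, `O=C(CCN1CCC(Cc2ccccc2)CC1)Nc1ccccc1F` — 0.28 ug/mL

Among the compounds with values here, in an assay on ileum with histamine H1 receptor (Cavia porcellus) as the target (a higher number here means a weaker inhibitor, a lower number a stronger inhibitor), compound 2 gives 0.28 ug/mL; its only neighbour is compound 1 at 0.2 ug/mL, and the step of a 1.4-fold higher number from compound 1 to compound 2 (0.15 log units; within the scatter) keeps the two together. Compound 3, `O=C(CCN1CCC(Cc2ccccc2)CC1)Nc1ccccc1`, differs from compound 2 by hydrogen in place of fluoro on an aromatic carbon. Within the data shown here, the one step that bears on this, a 1.4-fold higher number from compound 1 to compound 2 (0.15 log units; within the scatter), exchanges one halogen for another rather than removing it, so it gives only weak guidance. No step beyond the scatter is expected, at most a slight drift upward. Compound 3 is expected at 0.4 ug/mL, range 0.15 ug/mL to 1 ug/mL. The expected step is a 1.4-fold higher number from compound 2 to compound 3 (0.15 log units; within the scatter).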

Compound 3, half-maximal inhibitory concentration: 0.49 ug/mL
The estimate for compound 3 lay 1.2-fold (0.09 log units) below the measured number; low and high end bracket the measured number.
By their numbers in this assay, from the lowest: compounds 1, 2 and 3 (each within the scatter of the next, the first and the last beyond it).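

Hydrogen in place of chloro on this aromatic carbon gives the first step in the series beyond the scatter in this assay, with a 2.5-fold higher number from compound 1 to compound 3 (0.39 log units; beyond the scatter), although only a modest one. Hydrogen in place of fluoro stays within the scatter, with a 1.8-fold higher number from compound 2 to compound 3 (0.24 log units; within the scatter), so compound 2 cannot be separated from either compound 1 or compound 3. Nothing available here explains this difference between the two halogens. Open, as far as these compounds go, is how bromo, a methoxy group or an amine at this place would compare with chloro. Also open, from the compounds shown here alone, is whether chloro on another carbon of the ring would read the same.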